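The compounds below may be only part of what the source reports. "The series", "measured", "known", "first", "only" and "open" are said of these compounds alone.

Of the compounds shown here, three from this series have been tested in a functional assay on HeLa cells (Homo sapiens) for cytotoxicity, read by CCK-8 assay; on this read-out lower numbers stand for stronger inhibition and higher numbers for weaker inhibition. Compound 1, with the structure `Oc1cccc(-c2cc(-c3ccco3)cc(-c3cccc(O)c3)n2)c1`, gives 5990 nM in this assay. Compound 2, with the structure `Oc1ccc(-c2cc(-c3ccco3)cc(-c3cccc(O)c3)n2)cc1`, gives 5170 nM in this assay. Compound 3, with the structure `Oc1cccc(-c2cc(-c3cccnc3)cc(-c3ccccc3O)n2)c1`, gives 7530 nM in this assay, a number that lies within the usual scatter of both compound 1 and compound 2.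

For the measured compounds named here, the only single-point change among the measured compounds is 4-hydroxyphenyl in place of 3-hydroxyphenyl on an aromatic carbon. This change produced a 1.2-fold lower number from compound 1 to compound 2 (0.06 log units; within the scatter), a step within the scatter of repeated measurements. How the core of compound 1 differs from the core of compound 3 is not broken down here; the two differ in more than one place.

Compound 4, with the structure `Oc1ccc(-c2cc(-c3cccnc3)cc(-c3ccccc3O)n2)cc1`, has not yet been measured in this assay. Going by the values given here, it relates to compound 3 by 4-hydroxyphenyl in place of 3-hydroxyphenyl on an aromatic carbon, the same kind of change as the one from compound 1 to compound 2, though the surroundings differ: in compound 1 the place is meta to a 3-hydroxyphenyl group and meta to a furan-2-yl group, while in compound 3 it is meta to a 2-hydroxyphenyl group and meta to a pyridin-3-yl group. Because the earlier change gave a 1.2-fold lower number from compound 1 to compound 2 (0.06 log units; within the scatter), the step from compound 3 to compound 4 is expected to be small, estimated as a 1.2-fold lower number from compound 3 to compound 4 (0.08 log units; within the scatter). Compound 4 is therefore expected to give about 6300 nM in this assay, with a likely range from 3500 nM to 11500 nM.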

Compound 4, half-maximal inhibitory concentration: > 50000 nM
Compound 4 ended at the assay's limit; the forecaster's own chance of this, stated with the estimate: 5%; at least 7.9-fold (0.89 log units) between middle value and limit.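

In this assay, 4-hydroxyphenyl in place of 3-hydroxyphenyl gave an at least 6.6-fold higher number from compound 3 to compound 4 (0.82 log units; beyond the scatter), and the change therefore did not carry over from one core to the other with the same outcome: the same change on two cores in this assay, a 1.2-fold lower number (0.06 log units; within the scatter) from compound 1 to compound 2 and an at least 6.6-fold higher number (0.82 log units; beyond the scatter) from compound 3 to compound 4, at least 7.6-fold (0.88 log units) apart, beyond the scatter of two such steps

Compound 4 gives > 50000 nM, which is a limit of the assay and not a number, so the step on this core has a known lower bound but no known size. For the compounds shown here, with only one pair on each core, the result does not show which difference between the cores goes with the different outcome, the furan-2-yl group against the pyridin-3-yl group or the 3-hydroxyphenyl group against the 2-hydroxyphenyl group, and it gives no rule for any other core.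

The compounds shown leave open what the same change does on a core that combines the furan-2-yl group with the 2-hydroxyphenyl group, or the pyridin-3-yl group with the 3-hydroxyphenyl group, which would set these two differences apart. They also leave open whether a methoxy group or an amine in place of the hydroxyl group of the 4-hydroxyphenyl group would give a number like that of compound 3 or reach the limit like compound 4.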